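Adding a Second Chloro Group onto the Z-Configured Core

A few compounds are considered here, and "the series" means these few. Any claim that something is new, unique, unknown or untested is made for them only; others in the source may bear on it.

Compound 1 `CC(=O)OC/C(=C\c1ccc(Cl)cc1)C(=O)c1ccc(Cl)cc1` and compound 3 `CC(=O)OC/C(=C/c1ccc(Cl)cc1)C(=O)c1ccc(Cl)cc1` are built from the same atoms and bonds; their only difference is the two compounds have the same atoms and bonds and differ only in configuration as drawn: 1 of 1 stereo elements differ; a double bond is drawn E in compound 1 and Z in compound 3. In a functional assay on HeLa cells (Homo sapiens) for inhibition, read by sulforhodamine B assay, with a stated time of 48 h (a higher number here means a weaker inhibitor of growth, a lower number a stronger inhibitor of growth), compound 1 gives 19000 nM, while compound 3 gives 5700 nM, a step of a 3.3-fold lower number from compound 1 to compound 3 (0.52 log units; beyond the scatter) that rests on (the fact that compounds 1 and 3 differ only in the configuration as drawn). Compound 2 `CC(=O)OC/C(=C\c1ccc(Cl)cc1Cl)C(=O)c1ccc(Cl)cc1` differs from compound 1 by chloro in place of hydrogen on an aromatic carbon, and in this assay compound 2 gives 4600 nM, so that step is a 4.1-fold lower number from compound 1 to compound 2 (0.62 log units; beyond the scatter). Compound 4 `CC(=O)OC/C(=C/c1ccc(Cl)cc1Cl)C(=O)c1ccc(Cl)cc1` carries the same change, now made on the core of compound 3: chloro in place of hydrogen on an aromatic carbon. Because the step of a 4.1-fold lower number from compound 1 to compound 2 (0.62 log units; beyond the scatter) was clearly beyond the scatter, compound 4 is expected to show a step of a 3.4-fold lower number from compound 3 to compound 4 (0.53 log units; beyond the scatter) in this assay. Compound 4 is therefore estimated at 1700 nM, with a likely range from 700 nM to 4500 nM.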

Compound 4, concentration for 50% growth inhibition: 19000 nM
Estimate against measurement, compound 4: 11-fold (1.05 log units) below; the measured number lies above the stated range.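

In this assay, the change from 4-chlorophenyl to 2,4-dichlorophenyl gives a 3.3-fold higher number from compound 3 to compound 4 (0.52 log units; beyond the scatter) on this core, so the earlier gain does not carry over and the two steps run in opposite directions: the same change on two cores in this assay, a 4.1-fold lower number (0.62 log units; beyond the scatter) from compound 1 to compound 2 and a 3.3-fold higher number (0.52 log units; beyond the scatter) from compound 3 to compound 4, 14-fold (1.14 log units) apart, beyond the scatter of two such steps. With the second chloro group present, the change of double-bond configuration also reverses, giving a 4.1-fold higher number from compound 2 to compound 4 (0.62 log units; beyond the scatter) against a 3.3-fold lower number from compound 1 to compound 3 (0.52 log units; beyond the scatter) for the parent pair. This shows that, across these four compounds, the result of adding the chloro group depends on the core, but it does not show why, and one pair per core supports no general rule.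

The compounds shown leave open whether a methoxy or fluoro group entering at the same place would split between the two cores in the same way. They also leave open whether an amine in place of the acetoxy group would change this dependence.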